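Chlorine for Fluorine on the Benzamide of Compound 1

The source may hold more compounds than are shown below. What is called first, only, known or untested is meant among the compounds shown, and "the series" means these compounds.

This account follows a single change made to compound 1, whose structure is `CC(C)NC(=O)[C@H]1CC[C@@H](n2/c(=N/C(=O)c3ccc(F)c(F)c3)[nH]c3ccc(CN4CCC(C(C)(C)O)CC4)cc32)CC1`, and asks what it should do to clearance as read in an in vitro ADME assay on microsomes from liver (Homo sapiens) for metabolic stability; on this read-out higher numbers stand for fast clearance and lower numbers for slow clearance. Of the compounds shown here, three have been measured. Compound 1 gives 60 mL.min-1.g-1 in this assay. Compound 2, `CC(C)NC(=O)[C@H]1CC[C@@H](n2/c(=N/C(=O)c3ccc(F)cc3)[nH]c3ccc(CN4CC(C(C)(C)O)C4)cc32)CC1`, gives 105 mL.min-1.g-1, and this number and that of compound 1 are within the scatter of each other, so nothing separates them. Compound 3, `CCN(CC)C(=O)[C@H]1CC[C@@H](n2/c(=N/C(=O)c3ccccc3)[nH]c3ccc(CN4CCCCC4)cc32)CC1`, gives 364 mL.min-1.g-1, which lies well beyond the scatter from compound 1. Compound 1 therefore sits at the slow-clearance end of what has been measured, together with compound 2, while compound 3 is cleared much faster.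

Compound 4, `CC(C)NC(=O)[C@H]1CC[C@@H](n2/c(=N/C(=O)c3cc(F)cc(Cl)c3)[nH]c3ccc(CN4CCC(C(C)(C)O)CC4)cc32)CC1`, has not yet been run in this assay. It differs from compound 1 in one place: 3-chloro-5-fluorophenyl in place of 3,4-difluorophenyl on a carbonyl carbon. For the measured compounds named here, no measured pair shows this kind of exchange, so there is no step of the same type to lean on. With only compound 1 at 60 mL.min-1.g-1 as the anchor, the expected step of a 1.3-fold higher number from compound 1 to compound 4 (0.12 log units; within the scatter) is small, if anything upward, and not clearly beyond the scatter. Compound 4 is estimated at 80 mL.min-1.g-1, with a range from 40 mL.min-1.g-1 to 170 mL.min-1.g-1.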

Compound 4, intrinsic clearance in microsomes: 83 mL.min-1.g-1
The estimate for compound 4 lay 1.0-fold (0.02 log units) below the measured number, within the range that was stated.
By their numbers in this assay, from the lowest: compounds 1, 4 and 2 (each within the scatter of the next); then compound 3.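

The exchange of 3,4-difluorophenyl for 3-chloro-5-fluorophenyl on a carbonyl carbon gives, in this assay, a 1.4-fold higher number from compound 1 to compound 4 (0.14 log units; within the scatter), so the two compounds cannot be told apart on this read-out. For the compounds shown here, this is the first pair that differs in one place, and it shows directly that this position can take a ring carrying one fluorine and one chlorine, with the same count of heavy atoms, and that no change beyond the scatter appears when the rest of compound 1 is held fixed. Going by these compounds alone, nothing available bears on why the exchange leaves the read-out within the scatter, and the single pair offers no explanation of its own.

What the compounds shown leave open is whether this place stays as undemanding when the aryl group is of another kind, such as a pyridyl ring or a phenyl ring carrying a nitrile or a trifluoromethyl group. They also leave open whether the same exchange would read the same way on a compound that differs from compound 1 elsewhere, since one pair describes only one setting.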